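A few compounds are considered here, and "the series" means these few. Any claim that something is new, unique, unknown or untested is made for them only; others in the source may bear on it.

Values in an ADME assay on microsomes (Mus musculus) for metabolic stability, read by LC-MS, using NADPH, with a stated time of 1 h, tested at 1 uM (a lower number here means slower removal, a higher number faster removal of the compound), as follows:
- compound 1 `Nc1n[nH]c2cc(-c3ccc(=O)n(Cc4cccc(Cl)c4)c3)ccc12` gives < 10 mL.min-1.g-1 as a limit
- compound 2 `Nc1n[nH]c2cc(-c3ccc(=O)n(Cc4cccc(C(F)(F)F)c4)c3)ccc12` gives < 10 mL.min-1.g-1 as a limit

Both entries are limits of the assay, not numbers. Compound 2 stands at the limit < 10 mL.min-1.g-1 with no number to place it. Going by the values given here, the evidence so far is the limit of < 10 mL.min-1.g-1 in this assay, at which 2 of the 2 values shown sit, and the only measured step is a step that the two limits leave unreadable from compound 1 to compound 2 at the same place as the change now in view. Compound 3 `Nc1n[nH]c2cc(-c3ccc(=O)n(Cc4ccccc4)c3)ccc12` follows from compound 2 through hydrogen in place of trifluoromethyl on an aromatic carbon and leaves the shared core untouched. The measured step offers no size to carry over, so no change beyond the scatter is expected in this assay for this replacement. The estimated move is a step that the limit leaves unreadable from compound 2 to compound 3 with no direction favoured. For compound 3 the estimate is 7 mL.min-1.g-1 with an expected range of 3 mL.min-1.g-1 to 15 mL.min-1.g-1 and a report as a limit is likely.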

Compound 3, intrinsic clearance in microsomes: < 10 mL.min-1.g-1
Compound 3 was reported as a limit (the forecaster's own chance of this, stated with the estimate: 75%); the middle value is on the limit's open side.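

The steps among compound 1, compound 2 and compound 3 cannot be read, since all three are reported only as limits in this assay. The compounds shown leave open whether chloro, trifluoromethyl and hydrogen at this place differ in intrinsic clearance at all: the limit of < 10 mL.min-1.g-1 in this assay, at which 3 of the 3 values shown sit.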